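The compounds below may be only part of what the source reports. "The series", "measured", "known", "first", "only" and "open" are said of these compounds alone.

The series shares the core of compound 1 `CC(=O)NC1=CS(=O)(=O)O[C@@]12[C@@H](CO[Si](C)(C)C(C)(C)C)O[C@@H](n1cc(C)c(=O)n(C)c1=O)[C@@H]2O[Si](C)(C)C(C)(C)C`, varied only at the group on the carbonyl carbon. In a functional assay on HEL cells (Homo sapiens) for cytotoxicity, read by microscopy (on this read-out higher numbers stand for lower toxicity in this test and lower numbers for higher toxicity in this test), compound 1 gives a limit, >= 80000 nM. Compound 2 `Cc1cn([C@@H]2O[C@H](CO[Si](C)(C)C(C)(C)C)[C@@]3(OS(=O)(=O)C=C3NC(N)=O)[C@H]2O[Si](C)(C)C(C)(C)C)c(=O)n(C)c1=O` gives 16000 nM, and compound 3 `COC(=O)CC(=O)NC1=CS(=O)(=O)O[C@@]12[C@@H](CO[Si](C)(C)C(C)(C)C)O[C@@H](n1cc(C)c(=O)n(C)c1=O)[C@@H]2O[Si](C)(C)C(C)(C)C` gives 400000 nM, the highest of the two numbers read; the step of a 25-fold higher number from compound 2 to compound 3 (1.40 log units; beyond the scatter) is large, whereas an at least 5.0-fold lower number from compound 1 to compound 2 (0.69 log units; beyond the scatter) is left unreadable by the limit (the limit of >= 80000 nM in this assay, at which 1 of the 3 values shown sits). Compound 4 `Cc1cn([C@@H]2O[C@H](CO[Si](C)(C)C(C)(C)C)[C@@]3(OS(=O)(=O)C=C3NC(=O)NC(=O)c3ccccc3)[C@H]2O[Si](C)(C)C(C)(C)C)c(=O)n(C)c1=O` carries benzamido in place of (methoxycarbonyl)methyl on a carbonyl carbon. Benzamido, like the amino of compound 2, brings a hydrogen-bond donor onto the carbonyl carbon, so the earlier step of a 25-fold higher number from compound 2 to compound 3 (1.40 log units; beyond the scatter) is the nearest guide, read backwards. The step of a 4.0-fold lower number from compound 3 to compound 4 (0.60 log units; beyond the scatter) is therefore expected to be a lowering, though smaller than that. Compound 4 is estimated at 100000 nM, within 20000 nM to 400000 nM.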

Compound 4, minimum cytotoxic concentration: >= 80000 nM
Compound 4 was reported as a limit; the forecaster's own chance of this, stated with the estimate: 25%; the middle value lies beyond the limit too.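

In this assay compound 4 gives >= 80000 nM, which is a limit. Benzoyl in place of hydrogen on an amide-type nitrogen gives an at least 5.0-fold higher number from compound 2 to compound 4 (0.69 log units; beyond the scatter), so a hydrogen-bond donor on the carbonyl carbon does not by itself keep the low number of compound 2, since benzamido carries one as well. The steps to compound 4 from compound 1 and from compound 3 cannot be read: the limit of >= 80000 nM in this assay, at which 2 of the 4 values shown sit.

Open, on these data alone, is how much of the benzoyl is needed to raise the number. Methylamino or acetamido on the carbonyl carbon would separate a small substituent on that nitrogen from the aromatic ring.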